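Swapping the phenyl of compound 3 for nitro

This account rests on a few compounds, and the source may have more. Where it says the series, first, only, none or still open, it means among the compounds named here.

For compound 3 `O=C(NC(=O)c1ccccc1O)c1ccc(-c2ccccc2)cc1`, an ADME assay on L6 cells (Rattus norvegicus) for cytotoxicity, read by resazurin assay, with a stated time of 72 h (on this read-out lower numbers stand for stronger inhibition and higher numbers for weaker inhibition), reports only a limit, > 100 ug/mL. Two close relatives give real numbers: compound 1 `CC(C)c1ccc(C(=O)NC(=O)c2ccccc2O)cc1` reads 19 ug/mL, and compound 2 `CC(C)(C)c1ccc(C(=O)NC(=O)c2ccccc2O)cc1` reads 2.3 ug/mL.

The next compound, compound 4 `O=C(NC(=O)c1ccccc1O)c1ccc([N+](=O)[O-])cc1`, carries nitro in place of phenyl on an aromatic carbon, para to a large group: nitro in place of phenyl on an aromatic carbon.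

Among the measured compounds shown here, no measured compound here carries nitro, so the evidence is indirect. Phenyl in place of isopropyl gave an at least 5.2-fold higher number from compound 1 to compound 3 (0.72 log units; beyond the scatter), and phenyl in place of tert-butyl gave an at least 43-fold higher number from compound 2 to compound 3 (1.63 log units; beyond the scatter). Those two steps suggest that removing the phenyl should lower the number in this assay. Methyl in place of hydrogen gave an 8.3-fold lower number from compound 1 to compound 2 (0.92 log units; beyond the scatter), which shows that even a small change at this place moved the number beyond the usual scatter. The size of the next step is therefore hard to predict, and a moderate drop seems the fairest expectation, with some chance that the reading stays at the limit.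

The expected step is an at least 3.3-fold lower number from compound 3 to compound 4 (0.52 log units; beyond the scatter). The estimate for compound 4 is 30 ug/mL, with an expected range from 6 ug/mL to 100 ug/mL.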

Compound 4, half-maximal inhibitory concentration: 53 ug/mL
The estimate for compound 4 lay 1.8-fold (0.25 log units) below the measured number, within the range that was stated.
By their numbers in this assay, from the lowest: compound 2; then compound 1; then compound 4. At a limit, above all of these: compound 3.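

In this assay, nitro on this aromatic carbon gives a real reading, and that reading sits on the high side of both saturated groups. Nitro in place of tert-butyl gives a 23-fold higher number from compound 2 to compound 4 (1.36 log units; beyond the scatter), and nitro in place of isopropyl gives a 2.8-fold higher number from compound 1 to compound 4 (0.45 log units; beyond the scatter). Until now, only phenyl was tied to a higher number at this place, so nitro, which brings no ring, shows that a group without a ring can also raise the number from those of compound 1 and compound 2. Nitro in place of phenyl gives an at least 1.8-fold lower number from compound 3 to compound 4 (0.27 log units; that floor lies within the scatter). Compound 3 stands at a limit, so that step is only a floor: the limit of > 100 ug/mL in this assay, at which 1 of the 4 values shown sits.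

The compounds shown leave open whether an amine, a carboxylic acid or a longer chain on this aromatic carbon would read closer to compound 2 or closer to compound 4. These numbers give the order of the groups at this place, but they do not explain it.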